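Swapping a halogenated benzyl for cyclohexyl: permeability outlook

The source may report more compounds than this note shows. Statements on the series, on what has been measured and on what is new or still open speak of the compounds shown alone.

Compound 2 `Fc1ccc(Cc2ccc3c(NCCCNCc4ccco4)ccnc3c2)c(Cl)c1` sits level with its neighbours in an ADME assay for permeability, using PAMPA, with a stated time of 30 min, at pH 7.4; a higher number here means that the compound crosses the layer faster, a lower number that the compound crosses the layer more slowly: compound 2 gives 23 10^-6 cm/s, compound 1 `CCC(CC)c1ccc2c(NCCCNCc3cccc(OC)c3O)ccnc2c1` gives 23 10^-6 cm/s and compound 3 `COc1ccc(F)cc1CNCCCNc1ccnc2cc(Cc3ccc(F)cc3Cl)ccc12` gives 23 10^-6 cm/s. Among the measured compounds shown here, the only one-place step among the measured compounds, no change at the digits printed from compound 2 to compound 3 (within the scatter), came from putting 5-fluoro-2-methoxyphenyl in place of furan-2-yl on a saturated chain carbon bound to an amine nitrogen. Compound 4 `c1coc(CNCCCNc2ccnc3cc(C4CCCCC4)ccc23)c1` differs from compound 2 at another site: cyclohexyl in place of 2-chloro-4-fluorobenzyl on an aromatic carbon. For the measured compounds named here, no measured step touches that aromatic carbon; the values of compound 1 and compound 2 simply match. Going by the values given here, the one measured step was flat, so a step of no change at the digits printed from compound 2 to compound 4 (within the scatter) is expected, within the scatter. Compound 4 is therefore estimated at 23 10^-6 cm/s, between 12 10^-6 cm/s and 42 10^-6 cm/s.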

Compound 4, apparent permeability: 23 10^-6 cm/s
The estimate for compound 4 equals the measured number at the digits printed; the range from low to high includes it.
By their numbers in this assay, from the lowest: compounds 1, 2, 3 and 4 (each within the scatter of the next).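

In this assay this aromatic carbon now has a measured step of its own, with cyclohexyl in place of 2-chloro-4-fluorobenzyl giving no change at the digits printed from compound 2 to compound 4 (within the scatter). The read-out therefore stayed level when the aromatic ring, the chlorine and the fluorine of that group all left together. No measurement here offers a reason for this flat result. Going by these compounds, whether an amine or a carboxylic acid on this aromatic carbon would stay level remains open. Also open, on these data alone, is whether cyclohexyl would give the same result with 5-fluoro-2-methoxyphenyl in place of furan-2-yl.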